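Compound 3 and its 5,5-dimethyl counterpart, compound 4

The source may hold more compounds than are shown below. What is called first, only, known or untested is meant among the compounds shown, and "the series" means these compounds.

Among the measured compounds shown here, in an in vitro ADME assay on microsomes (Homo sapiens) for pharmacokinetics (on this read-out higher numbers stand for fast clearance and lower numbers for slow clearance), compound 3 (`O=C(NC1CC1)c1ccc(CN([C@@H]2CC(F)(F)CCNC2=O)S(=O)(=O)c2ccc(Cl)cc2)cc1`) gives 1.9 mL.min-1.g-1, the lowest of the three numbers measured so far. Compound 2 (`COc1ccc(CN([C@@H]2CC(F)(F)CCNC2=O)S(=O)(=O)c2ccc(Cl)cc2)cn1`) gives 9 mL.min-1.g-1, and compound 1 (`CC(C)(C)C1CCNC(=O)C(N(Cc2ccc(C(=O)NC3CC3)cc2)S(=O)(=O)c2ccc(Cl)cc2)C1`) gives 93 mL.min-1.g-1. Compound 4 (`CC1(C)CCNC(=O)[C@H](N(Cc2ccc(C(=O)NC3CC3)cc2)S(=O)(=O)c2ccc(Cl)cc2)C1`) has not yet been measured. It differs from compound 3 in one place, with 5,5-dimethyl-2-oxoazepan-3-yl in place of 5,5-difluoro-2-oxoazepan-3-yl on a sulfonamide nitrogen. For the measured compounds named here, one measured step bears on this change: a 49-fold lower number from compound 1 to compound 3 (1.69 log units; beyond the scatter). That step is large and beyond the scatter, and it ends at the same 5,5-difluoro-2-oxoazepan-3-yl group, there replacing 2-oxo-5-(tert-butyl)azepan-3-yl. Going by the values given here, the group entering compound 4, like the one in compound 1, carries no fluorine, so part of that step is expected to return in the opposite direction. A higher number beyond the scatter is therefore expected, with an estimated 11-fold higher number from compound 3 to compound 4 (1.02 log units; beyond the scatter). The estimate for compound 4 is 20 mL.min-1.g-1, with an expected range from 7 mL.min-1.g-1 to 55 mL.min-1.g-1.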

Compound 4, intrinsic clearance in microsomes: 36 mL.min-1.g-1
Estimate against measurement, compound 4: 1.8-fold (0.26 log units) below; low and high end bracket the measured number.
By their numbers in this assay, from the lowest: compound 3; then compound 2; then compound 4; then compound 1.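

In this assay, exchanging the 5,5-difluoro-2-oxoazepan-3-yl group for a 5,5-dimethyl-2-oxoazepan-3-yl group of the same heavy-atom count gives a 19-fold higher number from compound 3 to compound 4 (1.28 log units; beyond the scatter), so the change from fluorine to methyl matters at this place on the sulfonamide nitrogen even without a change in that count. Trimming the 2-oxo-5-(tert-butyl)azepan-3-yl group to the 5,5-dimethyl-2-oxoazepan-3-yl group gives only a 2.6-fold lower number from compound 1 to compound 4 (0.41 log units; beyond the scatter), a modest step. The low number of compound 3 therefore goes mostly with the 5,5-difluoro-2-oxoazepan-3-yl group and not simply with the loss of the tert-butyl group.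

On these data alone, whether a single fluorine, as in 5-fluoro-2-oxoazepan-3-yl, or a hydroxyl, as in 5-hydroxy-2-oxoazepan-3-yl, would keep the number close to that of compound 3 remains open. Nothing at hand explains the gap between the difluoro and dimethyl groups.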